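Swapping the Ring on the Amide Side Chain

A few compounds are considered here, and "the series" means these few. Any claim that something is new, unique, unknown or untested is made for them only; others in the source may bear on it.

Compound 1 `CCN(Cc1ccco1)C(=O)COc1ccc(C)cc1`: 489 nM
Compound 2 `CCN(Cc1cc[nH]c1)C(=O)COc1ccc(C)cc1`: 21800 nM
Compound 3 `CCN(Cc1cccnc1)C(=O)COc1ccc(C)cc1`: 15400 nM

All three were measured in an assay on HEK293 cells for agonist activity at transient receptor potential cation channel subfamily M member 8 (Homo sapiens), read by fluorescence and calcium flux, with a stated time of 15 min; a higher number here means that more compound is needed for the effect, a lower number that less compound is needed. Compound 3 stands second highest of the three numbers. Its nearest neighbour is seen in a 1.4-fold lower number from compound 2 to compound 3 (0.15 log units; within the scatter), which is within the scatter, and its furthest in a 31-fold higher number from compound 1 to compound 3 (1.50 log units; beyond the scatter), which is not.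

Compound 4 `CCN(Cc1cc[nH]n1)C(=O)COc1ccc(C)cc1` is the next member of this set. Compared with compound 3 it shows (1H-pyrazol-3-yl in place of pyridin-3-yl on a saturated chain carbon bound to an amide-type nitrogen).

Going by the values given here, two measured steps bear on this change. Both a 45-fold higher number from compound 1 to compound 2 (1.65 log units; beyond the scatter) and a 31-fold higher number from compound 1 to compound 3 (1.50 log units; beyond the scatter) were large, and in each the furan-2-yl ring gave way to a ring carrying a nitrogen; once that exchange had been made, a 1.4-fold lower number from compound 2 to compound 3 (0.15 log units; within the scatter) showed that a five-membered ring with one hydrogen-bond donor and a six-membered ring with none landed in the same place in this assay. The entering 1H-pyrazol-3-yl ring is, like the 1H-pyrrol-3-yl ring of compound 2, five-membered with one hydrogen-bond donor and one acceptor. Compound 4 is therefore expected to show a 1.2-fold higher number from compound 3 to compound 4 (0.07 log units; within the scatter), nothing beyond the scatter. The estimate for compound 4 in this assay is 18000 nM, with a range from 7000 nM to 45000 nM.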

Compound 4, half-maximal effective concentration: "not active" (no number reported)
Compound 4: no number reported; there is nothing to compare the estimate with.
By their numbers in this assay, from the lowest: compound 1; then compounds 3 and 2 (each within the scatter of the next).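

In this assay, going by these compounds alone, compound 4 is reported as "not active" with no number, so no step from compound 1, compound 2 or compound 3 to compound 4 can be read. Nothing measured here accounts for this result. The compounds shown leave open how far compound 4 lies from compound 3.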